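A furan-2-yl ring takes the place of phenyl

A few compounds are considered here, and "the series" means these few. Any claim that something is new, unique, unknown or untested is made for them only; others in the source may bear on it.

Compound 1 `Nc1nc(-c2ccccc2)nc2sc(-c3ccco3)nc12`: in a functional assay on CHO cells for antagonist activity at adenosine receptor A2b (Homo sapiens), read by cAMP accumulation, with a stated time of 10 min (a higher number here means a weaker inhibitor, a lower number a stronger inhibitor), compound 1 reaches only a limit, > 30000 nM.
Compound 2 `Nc1nc(-c2cccc(CO)c2)nc2sc(-c3ccco3)nc12`: compound 2 reaches only a limit, > 30000 nM.
Compound 3 `Nc1nc(-c2ccc(CO)cc2)nc2sc(-c3ccco3)nc12`: compound 3 reaches only a limit, > 30000 nM.

Compound 1 stands at the limit of this assay, and the same holds for all three measured compounds (the limit of > 30000 nM in this assay, at which 3 of the 3 values shown sit). Neither of the two measured steps can be read in size: the step that the two limits leave unreadable from compound 1 to compound 2 and the step that the two limits leave unreadable from compound 1 to compound 3 both run from one limit to another, so the hydroxymethyl group added to the phenyl ring leaves no readable trace in this assay.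

Compound 4 `Nc1nc(-c2ccco2)nc2sc(-c3ccco3)nc12` differs from compound 1 in one place: furan-2-yl in place of phenyl on an aromatic carbon. No measured step touches the phenyl ring itself; the two steps shown only add a group to it and are unreadable. There is therefore no measured evidence for a shift in either direction, and the shared core of compound 1 gives no number to build on.

Compound 4 is thus expected to sit at about 30000 nM in this assay, with a range from 6000 nM to 100000 nM. The step of a number no higher from compound 1 to compound 4 (the limit leaves the size open) is estimated as no change beyond the scatter, and a limit rather than a number is the likelier outcome for compound 4.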

Compound 4, half-maximal inhibitory concentration: > 30000 nM
Compound 4: no number, only a limit; the forecaster's own chance of this, stated with the estimate: 70%; the middle value lies on the limit itself.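

In this assay compound 4 gives only a limit, > 30000 nM. Compound 1 also gives only a limit, so the size of the change from compound 1 to compound 4 cannot be read. All the compounds shown sit at the same point: the limit of > 30000 nM in this assay, at which 4 of the 4 values shown sit. They leave open which change to the shared core, if any, would give a measurable value in this assay.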